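A few compounds are considered here, and "the series" means these few. Any claim that something is new, unique, unknown or untested is made for them only; others in the source may bear on it.

Going by the values given here, compound 1 (`O=S(=O)(CCO)c1cccc(-c2ccc3nccc(-c4ccncc4)c3n2)c1`) gives 95% in an ADME assay on microsomes from liver (Homo sapiens) for metabolic stability, read by LC-MS, using NADPH, with a stated time of 30 min, tested at 0.1 uM (on this read-out higher numbers stand for a more stable compound and lower numbers for a less stable compound), and stands highest of the three numbers so far. Compound 2 (`O=S(=O)(NCCO)c1cccc(Nc2ccc3nccc(-c4ccncc4)c3n2)c1`) gives 59% and compound 3 (`O=S(=O)(NCc1ccccc1)c1cccc(Nc2ccc3nccc(-c4ccncc4)c3n2)c1`) gives 42% on the same measure. Compound 4 (`Nc1cccc(-c2ccc3nccc(-c4ccncc4)c3n2)c1`) has amino in place of (2-hydroxyethyl)sulfonyl on an aromatic carbon. Among the compounds with values here, the one measured step, a number 17 percentage points lower from compound 2 to compound 3 (beyond the scatter) for phenyl in place of hydroxymethyl on a saturated chain carbon bound to a sulfonamide nitrogen, bears only loosely, and no measured pair tests this exchange. With compound 1 at 95% little room remains upward, so a fall is expected, a number 25 percentage points lower from compound 1 to compound 4 (beyond the scatter) as estimated. Compound 4 is estimated in this assay at 70% with an expected range from 45% to 90% overall.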

Compound 4, percent of the compound remaining: 78%
Compound 4: middle estimate off by 8 percentage points, on the low side; the range from low to high includes it.
By their numbers in this assay, from the lowest: compound 3; then compound 2; then compound 4; then compound 1.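

On an aromatic carbon of the six-membered aromatic ring of carbon only, meta to a large group, amino in place of (2-hydroxyethyl)sulfonyl gives a number 17 percentage points lower from compound 1 to compound 4 (beyond the scatter) in this assay. The step is modest although six heavy atoms leave and one enters, so the whole (2-hydroxyethyl)sulfonyl group is not needed for compound 4 to read 78%. No measured information explains the step.

Which part of the departing group carries the difference stays open. A methylsulfonyl group or an acetamide on the same carbon would separate the sulfonyl from the hydroxyethyl chain.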